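Amino in place of hydroxy: compound 3 to compound 4

This account rests on a few compounds, and the source may have more. Where it says the series, first, only, none or still open, it means among the compounds named here.

In an ADME assay on the whole organism (Rattus norvegicus, strain Sprague-Dawley), read by LC-MS, with a stated time of 30 min, at a dose of 1 mg/kg by the intravenous route (a higher number here means that the compound lasts longer, a lower number that the compound disappears faster), compound 1 `N#Cc1ccc(O[C@H]2CN(S(=O)(=O)c3ccc(Cl)cc3)C[C@@]2(O)CO)cc1F` gives 1.9 h and compound 2 `N#Cc1ccc(O[C@H]2CN(S(=O)(=O)c3ccc(C(F)(F)F)cc3)C[C@@]2(O)CO)cc1F` gives 2 h in this assay as well. Compound 3 `N#Cc1ccc(O[C@H]2CN(S(=O)(=O)c3ccc(Cl)cn3)C[C@@]2(O)CO)cc1F` gives 1.2 h in this assay and so holds the lowest number of the three, yet a 1.6-fold lower number from compound 1 to compound 3 (0.20 log units; within the scatter) and a 1.7-fold lower number from compound 2 to compound 3 (0.22 log units; within the scatter) are both within the scatter, as is a 1.1-fold higher number from compound 1 to compound 2 (0.02 log units; within the scatter) on the aromatic carbon. Compound 4 `N#Cc1ccc(O[C@H]2CN(S(=O)(=O)c3ccc(Cl)cn3)C[C@@]2(O)CN)cc1F` differs from compound 3 in that amino in place of hydroxy on a saturated chain carbon bound to a saturated ring carbon is made. Among the measured compounds shown here, none of the measured steps touches the hydroxymethyl, so they bear on this change only indirectly, all three having been small. For compound 4 the expected step is no change at the digits printed from compound 3 to compound 4 (within the scatter) and not beyond the scatter. Compound 4 is therefore estimated at 1.2 h with an expected span from 0.6 h to 2.4 h around it.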

Compound 4, mean residence time: 2.5 h
Estimate against measurement, compound 4: 2.1-fold (0.32 log units) below; measured number outside the range, above it.
By their numbers in this assay, from the lowest: compounds 3, 1, 2 and 4 (each within the scatter of the next, the first and the last beyond it).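

In this assay, aminomethyl in place of hydroxymethyl gives a 2.1-fold higher number from compound 3 to compound 4 (0.32 log units; beyond the scatter) and is the only step shown that lies beyond the scatter. Among the compounds shown here, the earlier steps, all in the group on the sulfonyl sulfur, stayed within it, so the saturated chain carbon bound to a saturated ring carbon is the one place so far where this read-out responds, seen in a single pair. No measurement at hand accounts for this step. Going by these compounds, whether the exchange carries over to the 4-chlorophenyl or 4-(trifluoromethyl)phenyl compounds remains open, as does the outcome with a dimethylaminomethyl group or a carboxylic acid there.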